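This account rests on a few compounds, and the source may have more. Where it says the series, first, only, none or still open, it means among the compounds named here.

Compounds measured in a functional assay on the whole organism for inhibition, with Mus musculus as the target, in the maximal electroshock model, at a dose of 30 mg/kg by the oral route; a lower number here means a weaker effect, a higher number a stronger effect of the compound at the dose given:
- compound 1 `CN1C(=O)NC2(CC2(C)C)C1=O`: 90%
- compound 2 `CCCCN1C(=O)NC2(CC2(C)C)C1=O`: 90%

Compound 2 stands level with compound 1 at the digits given: the step of no change at the digits printed from compound 1 to compound 2 (within the scatter) lies within the scatter of the method, so the two cannot be ordered against each other on these numbers. Compound 3 `CC1(C)CC12NC(=O)N(Cc1ccccc1)C2=O` has not yet been measured in this assay. It differs from compound 2 in one place: phenyl in place of propyl on a saturated chain carbon bound to an amide-type nitrogen in a ring.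

For the measured compounds named here, the only measured step that bears on this change is the one from compound 1 to compound 2, and it was flat within the scatter, though it exchanged hydrogen for propyl rather than propyl for phenyl, so it speaks to the same position but to a different group. Going by the values given here, with no measured step showing a shift at this position, and both measured compounds already at a high level of inhibition, the expectation for compound 3 is a step of a number 5 percentage points lower from compound 2 to compound 3 (within the scatter), that is, no change beyond the scatter. Compound 3 is therefore estimated at 85%, with a range from 60% to 100%.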

Compound 3, a percentage reported as inhibition, in the whole organism at one dose (the size of the read-out at that dose, not a potency): 70%
For compound 3 the middle estimate is 15 percentage points above the measured one; the measured number falls inside the stated range.
By their numbers in this assay, from the lowest: compound 3; then compounds 1 and 2 (each within the scatter of the next).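

The result shows that this position on a saturated chain carbon bound to an amide-type nitrogen in a ring is not indifferent to every group in this assay: phenyl in place of propyl gives a number 20 percentage points lower from compound 2 to compound 3 (beyond the scatter), whereas the earlier exchange of hydrogen for propyl gave only no change at the digits printed from compound 1 to compound 2 (within the scatter). Measured against the smaller group as well, phenyl in place of hydrogen gives a number 20 percentage points lower from compound 1 to compound 3 (beyond the scatter), so the fall appears from both compounds that lack the aromatic ring, and compound 3 still keeps a substantial 70% at the dose given. No measurement shown here accounts for this step.

The compounds shown leave open whether a longer chain or a cyclohexyl ring in place of phenyl would stay level with compound 2 or fall as compound 3 does, so the step cannot yet be assigned to the aromatic ring rather than to the larger number of carbons. As every number comes from a single dose, they tell only of a stronger or weaker effect at that dose.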